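Swapping Piperidinyl for Diethylamino on Two Related Cores

The source may hold more compounds than are shown below. What is called first, only, known or untested is meant among the compounds shown, and "the series" means these compounds.

Compound 1 `CN1CCN(C23CCN(CCCN4CCCCC4)C(C(c4ccccc4)C2)C(c2ccccc2)C3)CC1` and compound 2 `CCN(CC)CCCN1CCC2(N3CCN(C)CC3)CC(c3ccccc3)C1C(c1ccccc1)C2` share one core and differ in a single place, namely (diethylamino in place of piperidin-1-yl on a saturated chain carbon, three bonds along the chain from an amine nitrogen in a ring). In an ADME assay on L6 cells (Rattus norvegicus) for cytotoxicity, read by fluorescence, with a stated time of 72 h (on this read-out lower numbers stand for stronger inhibition and higher numbers for weaker inhibition), compound 1 gives 28900 nM, and compound 2 gives 68100 nM, so that the step shows a 2.4-fold higher number from compound 1 to compound 2 (0.37 log units; beyond the scatter). Compound 3 `CN1CCN(C23CC(NC(=O)CCN4CCCCC4)C(C(c4ccccc4)C2)C(c2ccccc2)C3)CC1` is built on a second core; the difference between the core of compound 1 and the core of compound 3 is not broken down here. In this assay compound 3 gives 15400 nM; its gap to compound 1 lies within the usual scatter, while only its gap to compound 2 lies beyond it.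

Compound 4 `CCN(CC)CCC(=O)NC1CC2(N3CCN(C)CC3)CC(c3ccccc3)C1C(c1ccccc1)C2` has not yet been measured. It differs from compound 3 by diethylamino in place of piperidin-1-yl on a saturated chain carbon, two bonds along the chain from a carbonyl carbon. This is the same kind of change as that between compound 1 and compound 2, but not the same change: there the exchange sat three bonds along the chain from an amine nitrogen in a ring, whereas here it sits two bonds along the chain from a carbonyl carbon. Going by the values given here, only one earlier instance of this kind of exchange is available, so any expectation rests on it alone. In this assay compound 4 is expected to show a step of about a 1.9-fold higher number from compound 3 to compound 4 (0.29 log units; within the scatter) because the earlier exchange gave a 2.4-fold higher number from compound 1 to compound 2 (0.37 log units; beyond the scatter). Compound 4 is therefore estimated at 30000 nM, within a range expected to run from 12000 nM to 75000 nM.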

Compound 4, half-maximal inhibitory concentration: 35900 nM
Compound 4: the middle estimate sits 1.2-fold (0.08 log units) below what was measured; the range from low to high includes it.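

In this assay, exchanging piperidin-1-yl for diethylamino on the second core gives a 2.3-fold higher number from compound 3 to compound 4 (0.37 log units; beyond the scatter). Set beside the earlier instance, the step carries over from one core to the other with no difference beyond the scatter: the same change on two cores in this assay, a 2.4-fold higher number (0.37 log units; beyond the scatter) from compound 1 to compound 2 and a 2.3-fold higher number (0.37 log units; beyond the scatter) from compound 3 to compound 4, 1.0-fold (0.00 log units) apart, within the scatter of two such steps. This shows that the change behaved alike in these two matched pairs, even though it sits two bonds along the chain from a carbonyl carbon in one and three bonds along the chain from an amine nitrogen in a ring in the other; it does not show that the same step would appear on any further core or in any other assay, and two pairs do not explain why the number rises.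

The compounds shown leave open whether other amines in place of piperidin-1-yl, such as dimethylamino, pyrrolidin-1-yl or morpholin-4-yl, would give a step of similar size and direction. They also leave open whether the exchange would give the same step on a longer chain, or whether a carboxylic acid in place of the amine would change the picture in this assay.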